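The source may hold more compounds than are shown below. What is called first, only, known or untested is meant among the compounds shown, and "the series" means these compounds.

Of the compounds shown here, three have been tested in a functional assay on IMR-32 cells (Homo sapiens) for inhibition, read by sulforhodamine B assay, with a stated time of 48 h, tested at 100 uM; on this read-out lower numbers stand for less inhibition of growth and higher numbers for more inhibition of growth at the one concentration tested. Compound 1 `O=c1c(C2N=C(c3ccccc3)SS2)coc2ccc(Cl)cc12` gives 92%. Compound 2 `O=c1c(C2N=C(c3ccccc3)SS2)coc2cc(Cl)c(Cl)cc12` differs from it by one added chloro on an aromatic carbon, and in this assay compound 2 gives 77%, a result that is a number 15 percentage points lower from compound 1 to compound 2 (beyond the scatter). Compound 3 `O=c1c(C(=S)Nc2ccccc2)coc2cc(Cl)c(Cl)cc12`, which carries a different sulfur-containing group on the shared core, gives 18% in this assay.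

Among the three numbers, compound 2 stands second highest: compound 1 lies above it by a step beyond the scatter, and compound 3 lies far below it, also beyond the scatter.

Compound 4 `O=c1c(C2N=C(c3ccccc3)SS2)coc2cc(Cl)ccc12` has not yet been measured. Compared with compound 2, the change is hydrogen in place of chloro on an aromatic carbon. Within the data shown here, the only measured step that bears on this change is the one from compound 1 to compound 2, where adding a chloro produced a number 15 percentage points lower from compound 1 to compound 2 (beyond the scatter); compound 4 removes a chloro instead, so the change runs the opposite way, although compound 4 is not the same molecule as compound 1. On that basis a modest rise in this assay is expected, a number 9 percentage points higher from compound 2 to compound 4 (within the scatter), and nothing larger. Compound 4 is therefore estimated at 86%, with a range from 72% to 96%.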

Compound 4, percent growth inhibition at one concentration: 53%
Compound 4: middle estimate off by 33 percentage points, on the high side, outside the stated range (below it).
By their numbers in this assay, from the lowest: compound 3; then compound 4; then compound 2; then compound 1.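

In this assay, the chloro at this place, ortho to a chloro group, goes with more inhibition of growth: putting hydrogen in its place gives a number 24 percentage points lower from compound 2 to compound 4 (beyond the scatter). The earlier step, a number 15 percentage points lower from compound 1 to compound 2 (beyond the scatter), concerned the other chloro of compound 2, where adding a chloro went with a lower number, so the two chloro groups of compound 2 do not act alike and a step at one place cannot be carried over to the other. Nothing available here explains why the two places differ.

From the compounds shown here alone, at this place only chloro and hydrogen appear, so it remains open whether fluoro, a methoxy group or an amine would give a number nearer to that of compound 2 or of compound 4. It is also open whether hydrogen in place of this chloro would lower the number in the same way on the different sulfur-containing group of compound 3, as no partner for that compound appears among those shown.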